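A Fluorine Swap on the Phenyl Ring of Compound 2

The source may report more compounds than this note shows. Statements on the series, on what has been measured and on what is new or still open speak of the compounds shown alone.

Of the compounds shown here, three sharing one core have been measured in a physicochemical assay for lipophilicity; on this read-out lower numbers stand for lower lipophilicity and higher numbers for higher lipophilicity. Compound 2 `C[C@H]1CC[C@@H]2[C@@H](OC(=O)[C@]23CC(c2ccccc2)=NO3)[C@]2(C)C(=O)C=C[C@@]12O` gives 1.41 and stands lowest of the three numbers. Among the compounds with values here, compound 1 `C[C@H]1CC[C@@H]2[C@@H](OC(=O)[C@]23CC(c2ccccc2Br)=NO3)[C@]2(C)C(=O)C=C[C@@]12O` gives 2.22; the step of a number 0.81 log units lower from compound 1 to compound 2 (beyond the scatter) is the only measured step that trades a halogen for hydrogen on the aromatic ring. Compound 3 `C[C@H]1CC[C@@H]2[C@@H](OC(=O)[C@]23CC(c2ccc(N(C)C)cc2)=NO3)[C@]2(C)C(=O)C=C[C@@]12O` gives 1.51, and the step of a number 0.10 log units higher from compound 2 to compound 3 (within the scatter) stays within the scatter.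

Compound 4 `C[C@H]1CC[C@@H]2[C@@H](OC(=O)[C@]23CC(c2ccccc2F)=NO3)[C@]2(C)C(=O)C=C[C@@]12O` has not yet been measured. Its difference from compound 2 is fluoro in place of hydrogen on an aromatic carbon. The measured step that bears on it is a number 0.81 log units lower from compound 1 to compound 2 (beyond the scatter), read in reverse: a halogen enters where hydrogen stood, so a rise is expected. Fluoro is counted as one heavy atom, and the expected rise is therefore smaller than that bromo step. Compound 4 is expected to give 1.65, with a range from 1.35 to 1.95. The expected step is a number 0.24 log units higher from compound 2 to compound 4 (within the scatter).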

Compound 4, partition coefficient: 1.58
Estimate against measurement, compound 4: 0.07 log units above; the range from low to high includes it.
By their numbers in this assay, from the lowest: compounds 2, 3 and 4 (each within the scatter of the next); then compound 1.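

In this assay, fluoro on this aromatic carbon, ortho to a large group, cannot be told apart from hydrogen, with a number 0.17 log units higher from compound 2 to compound 4 (within the scatter) as the step. The two halogens do not read alike at this position, as the direct swap of bromo for fluoro gives a number 0.64 log units lower from compound 1 to compound 4 (beyond the scatter), so the step from hydrogen to bromo does not carry over to fluoro. The 2-fluorophenyl and 4-(dimethylamino)phenyl compounds also stay level, with a number 0.07 log units higher from compound 3 to compound 4 (within the scatter) as their step, and no measurement at hand explains any of these steps.

As far as these compounds go, whether chloro at this position would read like fluoro or like bromo remains open. So does the outcome for a different kind of group there, such as a methoxy group or a carboxylic acid.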